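Cytotoxicity notes: pyridin-4-yl in place of 4-methylphenyl

The source may report more compounds than this note shows. Statements on the series, on what has been measured and on what is new or still open speak of the compounds shown alone.

Measured so far:
- Compound 1 `Cc1nc(-c2cccnc2)sc1-c1nnc(-c2ccccc2Cl)o1` — in an ADME assay on PANC-1 cells (Homo sapiens) for cytotoxicity, read by MTT assay (a lower number here means that less compound is tolerated, a higher number that more compound is tolerated), compound 1 gives > 100 ug/mL, which is a limit of the assay.
- Compound 2 `Cc1cccc(-c2nnc(-c3sc(-c4cccnc4)nc3C)o2)c1` — in this assay compound 2 gives > 100 ug/mL, again a limit.
- Compound 3 `Cc1ccc(-c2nnc(-c3sc(-c4cccnc4)nc3C)o2)cc1` — in this assay compound 3 gives > 100 ug/mL, also a limit.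

Compound 3 thus stands at the assay limit shared by every value in the set (the limit of > 100 ug/mL in this assay, at which 3 of the 3 values shown sit). Compound 4 `Cc1nc(-c2cccnc2)sc1-c1nnc(-c2ccncc2)o1` differs from compound 3 by pyridin-4-yl in place of 4-methylphenyl on an aromatic carbon. The measured steps a step that the two limits leave unreadable from compound 1 to compound 2, a step that the two limits leave unreadable from compound 1 to compound 3 and a step that the two limits leave unreadable from compound 2 to compound 3 are all unreadable because both ends sit at limits, so none gives a size or direction. The step that the limit leaves unreadable from compound 3 to compound 4 is therefore expected to show nothing beyond the scatter. Compound 4 is expected near 150 ug/mL, within 60 ug/mL to 400 ug/mL, most probably reported again only as a limit.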

Compound 4, half-maximal cytotoxic concentration: > 100 ug/mL
Compound 4: only a limit was reported (the forecaster's own chance of this, stated with the estimate: 80%); the middle value is on the limit's open side.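

No step to compound 4 from compound 1, compound 2 or compound 3 can be read, since all four compounds sit at one limit: the limit of > 100 ug/mL in this assay, at which 4 of the 4 values shown sit.

The compounds shown leave open whether exchanging these groups on the shared core changes the cytotoxic concentration in this assay at all.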